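The source may report more compounds than this note shows. Statements on the series, on what has been measured and on what is new or still open speak of the compounds shown alone.

Among the measured compounds shown here, in a physicochemical assay for solubility, read by HPLC, in phosphate buffer, at pH 6.8 (a lower number here means a less soluble compound, a higher number a more soluble compound), compound 1 `CC(C)C1=C(C(=O)N2[C@H](C)CC[C@H]2C(=O)N2CCN(C)CC2)SC2=N[C@@](C)(c3ccc(Cl)cc3)[C@@H](c3ccc(Cl)cc3)N21` gives 45 ug/mL and compound 2 `CC(=O)N1CCN(C(=O)[C@@H]2CC[C@@H](C)N2C(=O)C2=C(C(C)C)N3C(=N[C@@](C)(c4ccc(Cl)cc4)[C@H]3c3ccc(Cl)cc3)S2)CC1` gives 79 ug/mL, so compound 1 stands within the scatter of the only other number known. That single measured step, a 1.8-fold higher number from compound 1 to compound 2 (0.24 log units; within the scatter), puts acetyl in place of methyl on an amine nitrogen in a ring. Compound 3 `CC[C@@H]1CC[C@@H](C(=O)N2CCN(C)CC2)N1C(=O)C1=C(C(C)C)N2C(=N[C@@](C)(c3ccc(Cl)cc3)[C@H]2c2ccc(Cl)cc2)S1` differs from compound 1 elsewhere, by methyl in place of hydrogen on a saturated chain carbon bound to a saturated ring carbon, turning methyl to ethyl. For the measured compounds named here, no measured step covers this change, so the expected step in this assay is a 1.1-fold lower number from compound 1 to compound 3 (0.05 log units; within the scatter), nothing beyond the scatter. Compound 3 is estimated at 40 ug/mL, with an expected range of 18 ug/mL to 85 ug/mL.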

Compound 3, solubility: 13 ug/mL
Beside the measured number, compound 3's estimate is 3.1-fold (0.49 log units) above it, and the stated range ends above it.
By their numbers in this assay, from the lowest: compound 3; then compounds 1 and 2 (each within the scatter of the next).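

In this assay, the change from methyl to ethyl gives a 3.5-fold lower number from compound 1 to compound 3 (0.54 log units; beyond the scatter), the only step among these compounds that is printed as beyond the scatter. Adding one carbon at this saturated chain carbon bound to a saturated ring carbon therefore moves the reading measurably, even though the change is small and adds no charge. Nothing available explains this step. This single pair cannot show whether a longer chain, such as propyl, would lower the number further. It also leaves open whether a hydroxyl group on the ethyl would reverse the step.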